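Compound 4: a chlorophenyl variant of compound 3

The source may report more compounds than this note shows. Statements on the series, on what has been measured and on what is new or still open speak of the compounds shown alone.

Measured in a functional assay on A549 cells (Homo sapiens) for antiproliferative activity, read by MTT assay, with a stated time of 24 h; on this read-out higher numbers stand for weaker inhibition and lower numbers for stronger inhibition:
- compound 1 `O=c1[nH]cc(S(=O)(=O)Nc2cccc(-c3cn(-c4ccccc4)nn3)c2)c(=O)[nH]1`: 12700 nM
- compound 2 `Cc1ccccc1-n1cc(-c2cccc(NS(=O)(=O)c3c[nH]c(=O)[nH]c3=O)c2)nn1`: 5470 nM
- compound 3 `O=c1[nH]cc(S(=O)(=O)Nc2cccc(-c3cn(-c4ccccc4F)nn3)c2)c(=O)[nH]1`: a limit of the assay, > 20000 nM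

Compound 3 stands only at a limit in this assay, (the limit of > 20000 nM in this assay, at which 1 of the 3 values shown sits), so its true number is not known. Between the numbered compounds there is a 2.3-fold lower number from compound 1 to compound 2 (0.37 log units; beyond the scatter), and from them to compound 3 there are an at least 1.5-fold higher number from compound 1 to compound 3 (0.19 log units; that floor lies within the scatter) and an at least 3.6-fold higher number from compound 2 to compound 3 (0.56 log units; beyond the scatter). Compound 4 `O=c1[nH]cc(S(=O)(=O)Nc2cccc(-c3cn(-c4cccc(Cl)c4)nn3)c2)c(=O)[nH]1` carries 3-chlorophenyl in place of 2-fluorophenyl on an aromatic nitrogen. Both measured steps bear on the fluoro of compound 3, but none shows a chloro or a 3-chlorophenyl, so the direction of this change in this assay is uncertain; a return toward the range of compound 1 is as plausible as staying at the limit. Compound 4 is estimated at 9000 nM, within 3000 nM to 20000 nM. This estimate means an expected step of an at least 2.2-fold lower number from compound 3 to compound 4 (0.34 log units; beyond the scatter).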

Compound 4, half-maximal inhibitory concentration: 2430 nM
For compound 4 the middle estimate is 3.7-fold (0.57 log units) above the measured one; the measured number lies below the stated range.
By their numbers in this assay, from the lowest: compound 4; then compound 2; then compound 1. At a limit, above all of these: compound 3.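

In this assay the phenyl group on the aromatic nitrogen can carry a halogen and still gain activity, for 3-chlorophenyl gives a 5.2-fold lower number from compound 1 to compound 4 (0.72 log units; beyond the scatter) and a 2.3-fold lower number from compound 2 to compound 4 (0.35 log units; beyond the scatter). Against 2-fluorophenyl the change gives an at least 8.2-fold lower number from compound 3 to compound 4 (0.91 log units; beyond the scatter), so a halogen on this phenyl group does not in itself push the number up. Compound 3 stands at a limit of the assay: the limit of > 20000 nM in this assay, at which 1 of the 4 values shown sits. Between compound 3 and compound 4 the halogen and its place on the phenyl group change together, so the two cannot be separated, and the effect of a methoxy or an amine on this phenyl group stays open.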